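The source may report more compounds than this note shows. Statements on the series, on what has been measured and on what is new or still open speak of the compounds shown alone.

Three compounds from this series have been examined in a functional assay on HepG2 cells (Homo sapiens) for cytotoxicity, read by MTT assay, with a stated time of 72 h; a higher number here means a weaker inhibitor, a lower number a stronger inhibitor. Compound 1 `COc1ccc2ccc(=O)oc2c1C1=NNC(c2ccc(C)cc2)C1` gives 43 nM in this assay. Compound 2 `COc1ccc2ccc(=O)oc2c1C(/C=C/c1ccc(SC)cc1)=N/NC(N)=O` gives 99 nM. Compound 3 `COc1ccc2ccc(=O)oc2c1C1=NN(c2ccccc2)C(c2cccs2)C1` gives 15 nM. Among these three numbers compound 1 stands second highest: its nearest neighbour is compound 2, whose number is higher by a margin beyond the usual scatter, and the furthest is compound 3, whose number is lower by a margin also beyond the scatter.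

The next compound, compound 4 `COc1ccc2ccc(=O)oc2c1C1=NNC(c2ccc(C(F)(F)F)cc2)C1`, has not yet been measured. It is derived from compound 1 by a single change, (trifluoromethyl in place of methyl on an aromatic carbon). Among the measured compounds shown here, no pair of measured compounds in this set differs in just one place, so there is no directly comparable step to lean on. The three measured compounds differ from one another in this assay by margins beyond the scatter, and a substitution of this kind, on a six-membered aromatic ring of carbon only, gives no firm reason to expect a large move in either direction.

Compound 4 is therefore expected to land close to compound 1, with the step from compound 1 to compound 4 estimated as a 1.2-fold higher number from compound 1 to compound 4 (0.07 log units; within the scatter), which may well fall within the scatter. The estimate for compound 4 in this assay is 50 nM, with a plausible range from 20 nM to 130 nM.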

Compound 4, half-maximal inhibitory concentration: 13 nM
The estimate for compound 4 lay 3.8-fold (0.59 log units) above the measured number; the measured number lies below the stated range.
By their numbers in this assay, from the lowest: compounds 4 and 3 (each within the scatter of the next); then compound 1; then compound 2.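

Among the compounds shown here, compound 1 and compound 4 form the first pair in this set that differs in only one place, so the change can now be read directly. In this assay, the exchange of methyl for trifluoromethyl on an aromatic carbon of a six-membered aromatic ring of carbon only, para to a large group, gives a 3.3-fold lower number from compound 1 to compound 4 (0.52 log units; beyond the scatter) and moves the number in the direction of a stronger inhibitor. This shows that the result at this position depends on the group placed there, although this single modest step, resting on one pair, sets no trend, and nothing available explains why the number moves.

The compounds shown leave open how other groups at this place, such as a chlorine, a methoxy group, an amine or a carboxylic acid, would compare with methyl and trifluoromethyl. They also leave open whether the same exchange would give a step of similar size and direction elsewhere in the series, as this change is seen in one pair only.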